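The source may report more compounds than this note shows. Statements on the series, on what has been measured and on what is new or still open speak of the compounds shown alone.

Measured compounds:
Compound 1 `C=CCOC(=O)Nc1ccc([Se]C#N)cc1`: in an ADME assay on 184B5 cells (Homo sapiens) for cytotoxicity, read by MTT assay, with a stated time of 72 h (on this read-out higher numbers stand for weaker inhibition of growth and lower numbers for stronger inhibition of growth), compound 1 gives 9800 nM.
Compound 2 `N#C[Se]c1ccc(NC(=O)Oc2ccccc2)cc1`: in this assay compound 2 gives 22700 nM.

Compound 1 has the lowest number of the two, and the gap to compound 2 is larger than the usual scatter. The two share one core and differ only in the group hanging from the oxygen of the carbamate. For the measured compounds named here, the one step measured so far is a 2.3-fold higher number from compound 1 to compound 2 (0.36 log units; beyond the scatter). The unmeasured compound 3 `N#C[Se]c1ccc(NC(=O)OCc2ccccc2)cc1` makes a related move at the same end of the molecule: phenyl in place of vinyl on a saturated chain carbon bound to an oxygen next to a carbonyl group. Here the saturated chain carbon stays in place, so compound 3 sits between compound 1 and compound 2 in the way its groups are arranged. Going by the values given here, the measured step is the only guide, and it was modest, so the expected outcome is a similar or smaller rise in the number, a 1.4-fold higher number from compound 1 to compound 3 (0.15 log units; within the scatter). Compound 3 is therefore estimated at 14000 nM, with a range from 6000 nM to 33000 nM.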

Compound 3, concentration for total growth inhibition: 21900 nM
Beside the measured number, compound 3's estimate is 1.6-fold (0.19 log units) below it; measured number inside the range.
By their numbers in this assay, from the lowest: compound 1; then compounds 3 and 2 (each within the scatter of the next).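

In this assay, keeping the saturated chain carbon in place and putting phenyl where vinyl stood still gives a 2.2-fold higher number from compound 1 to compound 3 (0.35 log units; beyond the scatter), so a higher number with a phenyl end does not depend on the ring sitting directly on the carbamate oxygen. Compound 3 and compound 2 lie within the scatter of each other, so the presence or absence of that chain carbon makes no readable difference between these two phenyl compounds. Nothing available explains why the phenyl compounds give higher numbers than compound 1.

From the compounds shown here alone, it remains open whether the lower number of compound 1 belongs to its double bond, which a saturated propyl group in place of allyl would test. Also open, going by these compounds, is how this read-out would respond to an amine or a carboxylic acid on the phenyl ring of compound 3.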